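Notes on the aryl substituent series

A few compounds are considered here, and "the series" means these few. Any claim that something is new, unique, unknown or untested is made for them only; others in the source may bear on it.

Measured so far:
compound 1 `COc1ccc(C(=O)/C=C/c2ccc(F)cc2)c2c1C=CC(C)(C)O2`: > 10000 nM (a limit of the assay)
compound 2 `COc1ccc(C(=O)/C=C/c2ccc(-c3ccccc3)cc2)c2c1C=CC(C)(C)O2`: > 10000 nM (a limit of the assay)
compound 3 `COc1ccc(C(=O)/C=C/c2ccc(N3CCCC3)cc2)c2c1C=CC(C)(C)O2`: 8360 nM

In a functional assay on HT-29 cells (Homo sapiens) for antiproliferative activity, read by MTT assay, with a stated time of 24 h (on this read-out higher numbers stand for weaker inhibition and lower numbers for stronger inhibition), compound 1 gives > 10000 nM, which is a limit and not a number. Compound 2 likewise gives > 10000 nM, again a limit. For the measured compounds named here, compound 3 gives 8360 nM, the only number in the set, and it sits close to the limit of > 10000 nM in this assay, at which 2 of the 3 values shown sit. The steps of an at least 1.1-fold lower number from compound 1 to compound 3 (0.07 log units; that floor lies within the scatter) and an at least 1.1-fold lower number from compound 2 to compound 3 (0.07 log units; that floor lies within the scatter) lie within the scatter, and the step that the two limits leave unreadable from compound 1 to compound 2 cannot be read at all. Nothing in the set, therefore, separates the three aryl substituents beyond the scatter.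

Compound 4 `COc1ccc(C(=O)/C=C/c2ccc([N+](=O)[O-])cc2)c2c1C=CC(C)(C)O2` differs from compound 3 by nitro in place of pyrrolidin-1-yl on an aromatic carbon. Going by the values given here, no measured step involves nitro, so the expectation rests only on the three values: two substituents at this position gave limits and the third gave a number barely inside the measurable range. Compound 4 is therefore expected to give 12000 nM, with a range of 5000 nM to 30000 nM, and a limit rather than a number is a real possibility. The expected step is a 1.4-fold higher number from compound 3 to compound 4 (0.16 log units; within the scatter), within the scatter.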

Compound 4, half-maximal inhibitory concentration: 3730 nM
The estimate for compound 4 lay 3.2-fold (0.51 log units) above the measured number, outside the stated range (below it).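

In this assay, for the compounds shown here, this position now shows a readable difference between substituents, which the earlier compounds did not: nitro in place of pyrrolidin-1-yl gives a 2.2-fold lower number from compound 3 to compound 4 (0.35 log units; beyond the scatter). The change also reads beyond the scatter against the other two substituents, with an at least 2.6-fold lower number from compound 2 to compound 4 (0.42 log units; beyond the scatter) for nitro in place of phenyl and an at least 2.6-fold lower number from compound 1 to compound 4 (0.42 log units; beyond the scatter) for nitro in place of fluoro. Compound 4 is the strongest of the four, while compound 1 and compound 2 remain limits and not numbers: the limit of > 10000 nM in this assay, at which 2 of the 4 values shown sit.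

The compounds shown leave open whether this gain is particular to nitro or would also appear with a nitrile or a carboxylic acid on the same aromatic carbon. Going by these compounds, the full size of the steps from compound 1 and compound 2 also stays unknown, and the step between those two cannot be read.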